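Anilino for piperidinyl at the pyridine-type core of compound 2

A few compounds are considered here, and "the series" means these few. Any claim that something is new, unique, unknown or untested is made for them only; others in the source may bear on it.

Measured so far:
- compound 1, `CN1C(=O)[C@@]2(c3ccccc31)N(C)C[C@@H](c1cccs1)[C@@]21Cc2ccccc2C1=O`: 12.1%
- compound 2, `O=C(Nc1ccccc1)c1c(-c2ccc(Cl)cc2)cc(-c2ccccc2)nc1N1CCCCC1`: 13%
- compound 3, `Cc1ccc(NC(=O)c2c(-c3ccc(Cl)cc3)cc(-c3ccccc3)nc2N2CCCCC2)cc1`: 24%

In a functional assay on RPMI18226 cells (Homo sapiens) for antiproliferative activity, read by sulforhodamine B assay, with a stated time of 48 h, tested at 10 uM (on this read-out lower numbers stand for less inhibition and higher numbers for more inhibition at the one concentration tested (going by the name of the read-out)), compound 2 gives 13%, the second highest of the three numbers. Its nearest neighbour is compound 1, which in this assay gives 12.1%, a gap within the scatter, so no order between compound 1 and compound 2 can be read. Compound 3 stands furthest, a number 11 percentage points higher from compound 2 to compound 3 (beyond the scatter).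

The unmeasured compound 4, `COc1ccc(Nc2nc(-c3ccccc3)cc(-c3ccc(Cl)cc3)c2C(=O)Nc2ccccc2)cc1`, differs from compound 2 in one place: (4-methoxyphenyl)amino in place of piperidin-1-yl on an aromatic carbon. For the measured compounds named here, the only step recorded so far, from compound 2 to compound 3, concerns a different part of the shared core, a methyl on an aromatic carbon of the amide substituent, and was modest in size. Going by the values given here, no step shows what an exchange at the position next to the ring nitrogen does, so the expectation rests on the scatter of the three values and on the modest size of the one step seen.

A small rise at most is therefore expected for compound 4, a number 5 percentage points higher from compound 2 to compound 4 (within the scatter). The estimate for compound 4 in this assay is 18%, with a range from 5% to 35%.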

Compound 4, a percentage reported as inhibition, at one concentration (the size of the read-out at that concentration, not a potency): 30%
The estimate for compound 4 lay 12 percentage points below the measured number; the range from low to high includes it.
By their numbers in this assay, from the lowest: compounds 1 and 2 (each within the scatter of the next); then compounds 3 and 4 (each within the scatter of the next).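

In this assay, for the compounds shown here, the exchange of piperidin-1-yl for (4-methoxyphenyl)amino on the aromatic carbon next to the ring nitrogen amounts to a number 17 percentage points higher from compound 2 to compound 4 (beyond the scatter) and is the first step recorded at this position, which shows that the number responds to a change here as well as on the amide substituent. The exchange alters several things at once: a six-membered aromatic ring of carbon only replaces a six-membered non-aromatic ring with 1 hetero atom, and 1 hydrogen-bond donor enters where the leaving group has 0, so this single step cannot assign the rise to any one of these features. No measurement at hand bears on the reason for the rise.

Going by these compounds, whether the rise depends on the methoxy group, the amino hydrogen or the aromatic ring stays open; phenylamino, morpholin-4-yl or dimethylamino at this position would begin to separate these. Also open, on these data alone, is whether a methyl on the amide substituent, the change in compound 3, would add to this exchange when both are present in one compound.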